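Two propargyloxyphenyl arms on a shared core: one arm shifted

This account rests on a few compounds, and the source may have more. Where it says the series, first, only, none or still open, it means among the compounds named here.

Compound 2 `C#CCOc1ccc(-c2cc(-c3cccc(OCC#C)c3)nc(-c3ccccc3)n2)cc1` gives 25800 nM in an assay on BTI-TN-5B1-4 cells for inhibition of Amine oxidase [flavin-containing] A (Homo sapiens), read by fluorescence and Amplex Red, using microsomes, with a stated time of 30 min (on this read-out lower numbers stand for stronger inhibition and higher numbers for weaker inhibition), and is the only numbered entry in the series. Where compound 2 carries phenyl, compound 1 `C#CCOc1cccc(-c2cc(-c3cccc(OCC#C)c3)nc(N)n2)c1` carries an amino group, and compound 1 is reported as "not active" (no number reported) in this assay. Compound 3 `C#CCOc1cccc(-c2cc(-c3cccc(OCC#C)c3)nc(-c3ccccc3)n2)c1` differs from compound 2 by 3-(propargyloxy)phenyl in place of 4-(propargyloxy)phenyl on an aromatic carbon. For the measured compounds named here, no measured pair shows this swap, so the step is open. Both 3-(propargyloxy)phenyl arms of compound 3 are also present in compound 1, and compound 1 gives "not active" (no number reported), so a drift toward weaker inhibition, or nothing beyond the scatter, is expected. The expected step is a 1.6-fold higher number from compound 2 to compound 3 (0.19 log units; within the scatter). Compound 3 is estimated at 40000 nM, within 12000 nM to 150000 nM.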

Compound 3, half-maximal inhibitory concentration: "not active" (no number reported)
For compound 3 the study gives words and no number; the estimate stays without a comparison.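

For the compounds shown here, compound 3 is reported in words only in this assay, so no step from compound 2 to compound 3 can be read. As far as these compounds go, how swapping 4-(propargyloxy)phenyl for 3-(propargyloxy)phenyl shifts inhibition stays open. Nothing shown bears on this result.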